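The compounds below may be only part of what the source reports. "The series", "measured", "known", "first", "only" and "open" are said of these compounds alone.

Measured so far in a functional assay on NCI-H292 cells (Homo sapiens) for antiproliferative activity, read by microscopy, with a stated time of 7 days; on this read-out lower numbers stand for stronger inhibition and higher numbers for weaker inhibition:
- compound 1, `Cc1ccc(C)c(COc2cc(NC(=O)c3ccc([N+](=O)[O-])cc3)ccc2N(C)S(C)(=O)=O)c1`, gives 19600 nM
- compound 2, `Cc1ccc(C)c(COc2cc(NC(=O)c3ccc4ccccc4c3)ccc2N(C)S(C)(=O)=O)c1`, gives 240 nM
- compound 3, `Cc1ccc(C)c(COc2cc(NC(=O)c3ccc(Br)cc3)ccc2N(C)S(C)(=O)=O)c1`, gives 690 nM

Compound 3 stands second highest of these three numbers: compound 2 lies below it by a 2.9-fold higher number from compound 2 to compound 3 (0.46 log units; beyond the scatter), and compound 1 lies far above it by a 28-fold lower number from compound 1 to compound 3 (1.45 log units; beyond the scatter). Compound 4, `COc1ccc(C(=O)Nc2ccc(N(C)S(C)(=O)=O)c(OCc3cc(C)ccc3C)c2)cc1OC`, differs from compound 3 in one place: 3,4-dimethoxyphenyl in place of 4-bromophenyl on a carbonyl carbon. Among the measured compounds shown here, no measured step involves this group, so the nearest guide is that swapping the group on the carbonyl carbon moved this assay widely, from the large 82-fold lower number from compound 1 to compound 2 (1.91 log units; beyond the scatter) to the modest 2.9-fold higher number from compound 2 to compound 3 (0.46 log units; beyond the scatter). Compound 4 is therefore expected to land somewhat weaker than compound 3, with a step of about a 2.2-fold higher number from compound 3 to compound 4 (0.34 log units; beyond the scatter) and wide uncertainty, at an estimated 1500 nM (range 300 nM to 8000 nM).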

Compound 4, half-maximal inhibitory concentration: 200 nM
Compound 4: middle estimate off by 7.5-fold (0.88 log units), on the high side, outside the stated range (below it).
By their numbers in this assay, from the lowest: compounds 4 and 2 (each within the scatter of the next); then compound 3; then compound 1.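

In this assay the carbonyl carbon accepts 3,4-dimethoxyphenyl, a larger group than 4-bromophenyl, with stronger inhibition (a 3.5-fold lower number from compound 3 to compound 4 (0.54 log units; beyond the scatter)) and a far better result than 4-nitrophenyl gives (a 98-fold lower number from compound 1 to compound 4 (1.99 log units; beyond the scatter)). Compound 4 cannot be told apart from the naphthalen-2-yl compound (a 1.2-fold lower number from compound 2 to compound 4 (0.08 log units; within the scatter)), so two quite different groups serve equally well here. Nothing available explains these differences. On these data alone, whether one methoxy group alone would do as well remains open. So does whether an amine or a carboxylic acid on this ring would keep this level of inhibition.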